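Swapping 4-methoxyphenyl for 6-methoxypyridin-3-yl

This account rests on a few compounds, and the source may have more. Where it says the series, first, only, none or still open, it means among the compounds named here.

In a functional assay on HeLa cells (Homo sapiens) for antiproliferative activity, read by MTT assay, with a stated time of 72 h (on this read-out higher numbers stand for weaker inhibition and lower numbers for stronger inhibition), compound 1 `C=CC(=O)Nc1cccc(Oc2nc(Nc3cccc(OC)c3)nc3c2CSCC3)c1` gives 28900 nM and compound 2 `C=CC(=O)Nc1cccc(Oc2nc(Nc3ccc(OC)cc3)nc3c2CSCC3)c1` gives 20900 nM. These two numbers lie within the usual scatter of each other, so compound 2 stands level with compound 1. Compound 3 `C=CC(=O)Nc1cccc(Oc2nc(Nc3ccc(OC)nc3)nc3c2CSCC3)c1` keeps the shared core and carries 6-methoxypyridin-3-yl in place of 4-methoxyphenyl on a nitrogen on an aromatic ring. Among the compounds with values here, the one measured step at this place, a 1.4-fold lower number from compound 1 to compound 2 (0.14 log units; within the scatter), exchanged 3-methoxyphenyl for 4-methoxyphenyl and stayed within the scatter. On that evidence, no change beyond the scatter is expected in this assay, in either direction. Within the data shown here, no measured compound carries a ring with a hetero atom, so this guidance is indirect. The estimated step is a 1.1-fold higher number from compound 2 to compound 3 (0.02 log units; within the scatter). For compound 3 the estimated value is 22000 nM, with an expected range from 10000 nM to 45000 nM.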

Compound 3, half-maximal inhibitory concentration: 26300 nM
Estimate against measurement, compound 3: 1.2-fold (0.08 log units) below; measured number inside the range.
By their numbers in this assay, from the lowest: compounds 2, 3 and 1 (each within the scatter of the next).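

Swapping a carbon of the aromatic ring for a nitrogen, the first ring with a hetero atom at this position, makes no difference beyond the scatter in this assay (a 1.3-fold higher number from compound 2 to compound 3 (0.10 log units; within the scatter)), and the same holds against the other methoxyphenyl group (a 1.1-fold lower number from compound 1 to compound 3 (0.04 log units; within the scatter)). All three compounds therefore stand level, so 3-methoxyphenyl, 4-methoxyphenyl and 6-methoxypyridin-3-yl cannot be told apart on this nitrogen by this read-out. No accompanying measurement offers any explanation for these numbers.

On these data alone, all three groups are six-membered aromatic rings carrying a methoxy group, so it remains open how a plain phenyl, or a ring bearing an amine or a carboxylic acid, would behave. Also open, as far as these compounds go, is whether any group on this nitrogen can move the number beyond the scatter.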